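This account rests on a few compounds, and the source may have more. Where it says the series, first, only, none or still open, it means among the compounds named here.

Compound 1 `C/C=C/Cn1cc(/C=C/C(=O)CC(=O)C(=O)OCC)c2ccccc21` sits at the edge of what the numbers can say: in an assay on isolated protein for inhibition of DNA nucleotidylexotransferase (Homo sapiens), read by scintillation counting, with a stated time of 10 min (on this read-out higher numbers stand for weaker inhibition and lower numbers for stronger inhibition), compound 1 gives only a limit, > 40 uM. Compound 2 `CCOC(=O)C(=O)CC(=O)/C=C/c1cn(-c2ccccc2)c2ccccc12` likewise gives only a limit, > 40 uM. Compound 3 `CCOC(=O)C(=O)CC(=O)/C=C/c1cn(Cc2ccc(Cl)cc2)c2ccccc12` gives 40 uM in this assay, a number rather than a limit, though it stands right at the limit of > 40 uM in this assay, at which 2 of the 3 values shown sit. The change from compound 1 to compound 4 `CCOC(=O)C(=O)CC(=O)/C=C/c1cn(Cc2ccc(C#N)cc2)c2ccccc12` is 4-cyanophenyl in place of prop-1-en-1-yl on a saturated chain carbon bound to an aromatic nitrogen. Among the compounds with values here, two measured steps bear on it. The step of a number no higher from compound 1 to compound 3 (the limit leaves the size open) swaps the same prop-1-en-1-yl for a 4-chlorophenyl at the same place, and the step of a number no higher from compound 2 to compound 3 (the limit leaves the size open) arrives at the same 4-chlorobenzyl, while the step that the two limits leave unreadable from compound 1 to compound 2 cannot be read at all. Since compound 3 sits at 40 uM, a 4-cyanophenyl at the same place is expected to land near that number, so the expected step is a number no higher from compound 1 to compound 4 (the limit leaves the size open). Compound 4 is therefore estimated at 40 uM, within a range from 15 uM to 150 uM, with a fair chance that this assay again reports only a limit.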

Compound 4, concentration for 50% inhibition: > 40 uM
Compound 4: only a limit was reported (the forecaster's own chance of this, stated with the estimate: 50%); the middle value sits exactly at the limit.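

In this assay, cyano in place of chloro on an aromatic carbon gives a number no lower from compound 3 to compound 4 (the limit leaves the size open), so this change brings no gain in inhibition over the 4-chlorobenzyl group. Compound 4 gives > 40 uM, which is a limit, and the steps that join it to compound 1 and compound 2 cannot be read. Among the groups at this place, on a saturated chain carbon bound to an aromatic nitrogen, the 4-chlorophenyl of compound 3 remains the only one with a number, and the 4-cyanophenyl does not add a second: the limit of > 40 uM in this assay, at which 3 of the 4 values shown sit.

From the compounds shown here alone, the size of the step from chloro to cyano stays open, as does any ranking of compound 1, compound 2 and compound 4. Going by these compounds, how an amine or a carboxylic acid in place of the cyano would read also stays open.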